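The compounds below may be only part of what the source reports. "The series", "measured", "known", "first", "only" and "open" are said of these compounds alone.

Measured compounds:
- compound 1, `COc1ccc(C(=O)c2ccc3c(ccn3S(=O)(=O)c3cccc(/C=C/C(=O)NO)c3)c2)cc1`, 751 nM in an assay on isolated protein for inhibition of protein deacetylase HDAC6 (Homo sapiens); on this read-out lower numbers stand for stronger inhibition and higher numbers for weaker inhibition
- compound 2, `COc1ccc(C(=O)c2ccc3c(ccn3Cc3ccc(C(=O)NO)cc3)c2)cc1OC`, 15.5 nM in this assay
- compound 3, `COc1cc(C(=O)c2ccc3c(ccn3Cc3ccc(C(=O)NO)cc3)c2)cc(OC)c1OC`, 1540 nM in this assay

Compound 2 gives the lowest number of the three in this assay, and both of its neighbours sit far away: compound 1 shows a much higher number, and the single-point step a 99-fold higher number from compound 2 to compound 3 (2.00 log units; beyond the scatter) is large and well beyond the scatter. So among the measured compounds, compound 2 stands alone as the strongest inhibitor.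

Compound 4, `O=C(NO)c1ccc(Cn2ccc3cc(C(=O)c4ccc(Cl)cc4)ccc32)cc1`, has not yet been measured in this assay. It differs from compound 2 at the carbonyl carbon: 4-chlorophenyl in place of 3,4-dimethoxyphenyl on a carbonyl carbon. Within the data shown here, the only measured step at the same part of the molecule, a 99-fold higher number from compound 2 to compound 3 (2.00 log units; beyond the scatter), shows that this region is sensitive, and that adding a methoxy there weakened inhibition sharply. Here two methoxy groups are taken away and a chlorine put in their place, a change in the opposite sense for which no direct precedent exists among the measured compounds. The expectation is therefore a modest weakening, with wide uncertainty: the step of a 2.6-fold higher number from compound 2 to compound 4 (0.41 log units; beyond the scatter) is expected. Compound 4 is estimated at 40 nM, within 8 nM to 200 nM.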

Compound 4, half-maximal inhibitory concentration: 6.73 nM
Compound 4: middle estimate off by 5.9-fold (0.77 log units), on the high side; the measured number lies below the stated range.
By their numbers in this assay, from the lowest: compound 4; then compound 2; then compound 1; then compound 3.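

In this assay, the group on the carbonyl carbon can lose both methoxy groups and take on a chlorine with no loss of inhibition: the change to 4-chlorophenyl brings a 2.3-fold lower number from compound 2 to compound 4 (0.36 log units; beyond the scatter), a gain that is modest but real. Among these compounds, the only earlier step at this place, a 99-fold higher number from compound 2 to compound 3 (2.00 log units; beyond the scatter), showed just a loss, so the number here can now be seen to move in either direction, and strong inhibition does not depend on the methoxy groups of compound 2. Nothing measured here accounts for the drop in the number, so it can be described but not explained.

This single step removes two methoxy groups and adds a chlorine at once, so the compounds shown cannot separate those two changes. A plain phenyl ring, a 4-fluorophenyl or a 4-aminophenyl at this place would help to tell them apart.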